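Anilide variants of a shared core: working notes

The compounds below may be only part of what the source reports. "The series", "measured", "known", "first", "only" and "open" are said of these compounds alone.

Measured so far:
compound 1 `COc1cc2c(cc1OC)C(CC(=O)O)CC2`, which in a functional assay on the whole organism (strain Wistar) for inhibition, with Rattus norvegicus as the target, read by paw edema, with a stated time of 4 h, at a dose of 100 mg/kg (on this read-out lower numbers stand for less inhibition and higher numbers for more inhibition at the one dose given (going by the name of the read-out)), gives 23.9%
compound 2 `COc1cc2c(cc1OC)C(CC(=O)Nc1ccc(Cl)cc1)CC2`, which gives 60.9%
compound 3 `COc1cc2c(cc1OC)C(CC(=O)Nc1ccc([N+](=O)[O-])cc1)CC2`, which gives 37.5%

Compound 2 stands highest of the three numbers; compound 3 is nearest and compound 1 furthest, both gaps beyond the scatter. Compound 4 `COc1cc2c(cc1OC)C(CC(=O)Nc1ccccn1)CC2` differs from compound 2 by pyridin-2-yl in place of 4-chlorophenyl on an amide-type nitrogen. Going by the values given here, two steps bear on this: a number 37 percentage points higher from compound 1 to compound 2 (beyond the scatter), a large step at the same amide-type nitrogen, and a number 23.4 percentage points lower from compound 2 to compound 3 (beyond the scatter), a modest step from exchanging one group on the aromatic ring. Replacing the whole ring is therefore expected to move the number, most likely downward and by a modest step; the expected step is a number 15.9 percentage points lower from compound 2 to compound 4 (beyond the scatter). Compound 4 is estimated at 45%, with a range from 30% to 62%.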

Compound 4, a percentage reported as inhibition, in the whole organism at one dose (the size of the read-out at that dose, not a potency): 29.7%
The estimate for compound 4 lay 15.3 percentage points above the measured number; the measured number lies below the stated range.
By their numbers in this assay, from the lowest: compounds 1, 4 and 3 (each within the scatter of the next, the first and the last beyond it); then compound 2.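

Pyridin-2-yl in place of 4-chlorophenyl on the amide-type nitrogen in this assay gives a number 31.2 percentage points lower from compound 2 to compound 4 (beyond the scatter), so the ring carried by this nitrogen matters, not only the group on the aromatic ring. (Pyridin-2-yl)amino in place of hydroxy on the carbonyl carbon gives a number 5.8 percentage points higher from compound 1 to compound 4 (within the scatter), so the amide alone does not secure the higher number seen for compound 2. No measurement at hand accounts for the difference between the two rings.

Open, from the compounds shown here alone, is whether the ring nitrogen or the loss of chloro lies behind this step. A plain phenyl on the same nitrogen would separate the two.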